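Cytotoxicity of a Thiazolidinone Series Toward a Liver Cell Line

The compounds below may be only part of what the source reports. "The series", "measured", "known", "first", "only" and "open" are said of these compounds alone.

Compound 1 `CC(C)CN1C(=O)/C(=C/c2ccc(Cl)cc2)S/C1=N\c1ccccc1` has no number in an ADME assay on HepG2 cells (Homo sapiens) for cytotoxicity, read by MTT assay, with a stated time of 48 h; a higher number here means a weaker inhibitor, a lower number a stronger inhibitor; for compound 1 the entry reads "not determined" (no result reported), and no result was reported. The same holds for compound 2 `CC(C)CN1C(=O)/C(=C/c2ccc(O)cc2)S/C1=N\c1ccccc1`, for which the entry in this assay is likewise "not determined" (no result reported), without a reported value. Among the measured compounds, compound 3 `Cc1ccsc1/C=C1\S/C(=N\c2ccccc2)N(CC(C)C)C1=O` gives 89200 nM in this assay, a weak effect. The unmeasured compound 4 `COc1cc(/C=C2\S/C(=N\c3ccccc3)N(CC(C)C)C2=O)ccc1O` differs from compound 1 by 4-hydroxy-3-methoxyphenyl in place of 4-chlorophenyl on a double-bonded chain carbon bound to a double-bonded ring carbon. Among the measured compounds shown here, no step between measured compounds is available to size this change, so its direction in this assay is uncertain; given the weak result of compound 3, the expectation is that compound 4 also remains a weak inhibitor, with any shift of the same order as the scatter. Compound 4 is therefore estimated at 80000 nM in this assay, within a range from 30000 nM to 200000 nM.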

Compound 4, half-maximal inhibitory concentration: 89500 nM
Beside the measured number, compound 4's estimate is 1.1-fold (0.05 log units) below it; the measured number falls inside the stated range.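

In this assay, the step of a 1.0-fold higher number from compound 3 to compound 4 (0.00 log units; within the scatter) gives the first measured size for a change on this double-bonded chain carbon bound to a double-bonded ring carbon. It lies within the scatter, so 3-methylthiophen-2-yl and 4-hydroxy-3-methoxyphenyl cannot be told apart here, even though one is a sulfur-containing ring and the other a six-membered aromatic ring of carbon only. Still open, as far as these compounds go, is whether an amine or a carboxylic acid at this place would move the number beyond the scatter. No measured evidence accounts for this result.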